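This account rests on a few compounds, and the source may have more. Where it says the series, first, only, none or still open, it means among the compounds named here.

Working notes on a three-membered set sharing one core, read in a functional assay on the whole organism (strain Wistar) for inhibition, with Rattus norvegicus as the target, read by paw edema, with stated times of 30 min and 120 min, at a dose of 50 mg/kg by the oral route; on this read-out lower numbers stand for less inhibition and higher numbers for more inhibition at the one dose given (going by the name of the read-out). Compound 1 `Fc1ccc(C2=NN(c3ccccc3)C(c3cn(-c4ccccc4)nc3-c3ccc(Cl)c(Cl)c3)C2)cc1` gives 60.2%; compound 2 `CCC(=O)N1N=C(c2ccc(F)cc2)CC1c1cn(-c2ccccc2)nc1-c1ccc(Cl)c(Cl)c1` gives 75.6%; compound 3 `Fc1ccc(C2=NNC(c3cn(-c4ccccc4)nc3-c3ccc(Cl)c(Cl)c3)C2)cc1` gives 46.1%. Compound 2 stands highest of the three numbers: the step of a number 15.4 percentage points higher from compound 1 to compound 2 (beyond the scatter) and the step of a number 29.5 percentage points lower from compound 2 to compound 3 (beyond the scatter) are both beyond the scatter, and so is a number 14.1 percentage points lower from compound 1 to compound 3 (beyond the scatter). All three known steps concern only the group on the amine nitrogen in the ring, with propanoyl sitting above phenyl and phenyl above hydrogen.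

Compound 4 `CCC(=O)N1N=C(c2ccc(Cl)cc2)CC1c1cn(-c2ccccc2)nc1-c1ccc(Cl)c(Cl)c1` keeps the propanoyl of compound 2 and changes another part of the molecule: chloro in place of fluoro on an aromatic carbon. Among the compounds with values here, no measured pair in the set alters the 4-fluorophenyl, so none of the three steps bears on this change; the data carry no information on it either way. The expectation is therefore a number for compound 4 close to that of compound 2, with no step beyond the scatter. The expected step is a number 0.6 percentage points lower from compound 2 to compound 4 (within the scatter). Compound 4 is estimated at 75%, in the range 62% to 86%.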

Compound 4, a percentage reported as inhibition, in the whole organism at one dose (the size of the read-out at that dose, not a potency): 68.8%
For compound 4 the middle estimate is 6.2 percentage points above the measured one, and the stated range covers the measured number.
By their numbers in this assay, from the lowest: compound 3; then compounds 1, 4 and 2 (each within the scatter of the next, the first and the last beyond it).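

In this assay, within the data shown here, this is the first reading at the aromatic carbon para to a large group, and the change from 4-fluorophenyl to 4-chlorophenyl, with propanoyl kept on the amine nitrogen in the ring, gives a number 6.8 percentage points lower from compound 2 to compound 4 (within the scatter). All earlier steps concerned the group on that nitrogen and lay beyond the scatter, so in this pair the position accepts chloro in place of fluoro with no step beyond the scatter. No measurement at hand speaks to what lies behind this result.

The compounds shown leave open whether the same exchange stays within the scatter with phenyl or hydrogen on the ring nitrogen. They also leave open how a methoxy, an amine or a carboxylic acid at this position would read.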